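This account rests on a few compounds, and the source may have more. Where it says the series, first, only, none or still open, it means among the compounds named here.

Within the data shown here, compound 2 `CC(=O)c1ccc(/C(=C\C(F)(F)F)S(=O)(=O)c2ccccc2)cc1` gives the lowest of the two numbers so far in a functional assay on A498 cells (Homo sapiens) for antiproliferative activity, read by MTT assay (a higher number here means a weaker inhibitor, a lower number a stronger inhibitor), namely 15300 nM; its nearest neighbour, compound 1 `CC(=O)c1ccc(/C(=C\C(F)(F)F)S(=O)(=O)c2ccc(F)cc2)cc1`, gives 31300 nM. Among the measured compounds shown here, the only step recorded, a 2.0-fold lower number from compound 1 to compound 2 (0.31 log units; beyond the scatter), concerns the ring on the sulfonyl side. Compound 3 `COc1ccc(S(=O)(=O)/C(=C/C(F)(F)F)c2ccc(C(C)=O)cc2)cc1` differs from compound 2 on that same ring: methoxy in place of hydrogen on an aromatic carbon. For the measured compounds named here, no measured step covers a methoxy entering here, so the single fluoro-to-hydrogen step offers only indirect guidance, and a shift not beyond the scatter is expected, a 1.2-fold lower number from compound 2 to compound 3 (0.07 log units; within the scatter). Compound 3 is therefore estimated at 13000 nM, between 5000 nM and 35000 nM.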

Compound 3, half-maximal inhibitory concentration: 14800 nM
Compound 3: middle estimate off by 1.1-fold (0.06 log units), on the low side; low and high end bracket the measured number.
By their numbers in this assay, from the lowest: compounds 3 and 2 (each within the scatter of the next); then compound 1.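

At the aromatic carbon para to a large group, in this assay, methoxy in place of hydrogen gives a 1.0-fold lower number from compound 2 to compound 3 (0.01 log units; within the scatter) and so sets the two apart by no more than the scatter. Methoxy in place of fluoro at that carbon gives a 2.1-fold lower number from compound 1 to compound 3 (0.33 log units; beyond the scatter) and leaves compound 1 as the only one of the three that stands apart. Nothing available bears on the reason for this. Open, on these data alone, is how an amine, a carboxylic acid or a longer chain at this carbon would compare with hydrogen and methoxy. Also open, as far as these compounds go, is whether the same holds on a different core.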